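Allyl for benzyl on the oxyamide in two cores

The compounds below may be only part of what the source reports. "The series", "measured", "known", "first", "only" and "open" are said of these compounds alone.

Compound 1 `CC(C(=O)NOCc1ccccc1)N1C(=O)CSC1=O` and compound 2 `C=CCONC(=O)C(C)N1C(=O)CSC1=O` share one core; compound 3 `O=C(CN1C(=O)S/C(=C\c2ccc(F)cc2)C1=O)NOCc1ccccc1` and the unmeasured compound 4 `C=CCONC(=O)CN1C(=O)S/C(=C\c2ccc(F)cc2)C1=O` share another, and the difference between the two cores is not broken down here. In an ADME assay on RAW264.7 cells (Mus musculus) for cytotoxicity, read by neutral red uptake, with a stated time of 24 h (on this read-out higher numbers stand for lower toxicity in this test and lower numbers for higher toxicity in this test), compound 1 gives > 128000 nM, which is a limit of the assay rather than a number. In this assay compound 2 gives > 128000 nM, again a limit. The change between them is vinyl in place of phenyl on a saturated chain carbon bound to an oxygen, and the step that the two limits leave unreadable from compound 1 to compound 2 cannot be sized because of the limit of > 128000 nM in this assay, at which 3 of the 3 values shown sit. In this assay compound 3 gives > 128000 nM, also a limit. Compound 4 carries the same change on its core: vinyl in place of phenyl on a saturated chain carbon bound to an oxygen. Among the compounds with values here, no measured pair here yields a readable size for this change. The expectation for compound 4 rests first on compound 3, whose value > 128000 nM is a limit. It rests further on compound 2, whose value > 128000 nM is a limit reached after the same change. Compound 4 is therefore expected to stay at the limit, with the step that the limit leaves unreadable from compound 3 to compound 4 estimated as flat. The estimate for compound 4 is 200000 nM, expected between 100000 nM and 600000 nM.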

Compound 4, half-maximal cytotoxic concentration: > 128000 nM
Compound 4: only a limit was reported (the forecaster's own chance of this, stated with the estimate: 90%); the middle value lies beyond the limit too.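

The step from compound 3 to compound 4 cannot be read in this assay because both values are limits, not numbers: the limit of > 128000 nM in this assay, at which 4 of the 4 values shown sit.

The compounds shown leave open whether allyl in place of benzyl alters cytotoxicity in either core, and at what concentration, if any, compounds 1, 2, 3 or 4 would become toxic in this assay.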